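Phenyl in place of methyl on the series

The source may report more compounds than this note shows. Statements on the series, on what has been measured and on what is new or still open speak of the compounds shown alone.

Within the data shown here, in a functional assay on DU-145 cells (Homo sapiens) for cytotoxicity, read by MTT assay, with a stated time of 48 h (on this read-out higher numbers stand for weaker inhibition and lower numbers for stronger inhibition), compound 2 (`COc1cc(C2=NOC(COCc3cn(Cc4cc(C)cnc4Cl)nn3)C2)cc(OC)c1OC`) gives 58900 nM and compound 1 (`COc1cc(C2CC(COCc3cn(Cc4cc(-c5ccc(F)cc5)cnc4Cl)nn3)ON2C=O)cc(OC)c1OC`) gives 32800 nM with the two values within the scatter of each other, so compound 2 stands level with the only other measured compound. Compound 3 (`COc1cc(C2=NOC(COCc3cn(Cc4cc(-c5ccccc5)cnc4Cl)nn3)C2)cc(OC)c1OC`) keeps the core of compound 2 and carries phenyl in place of methyl on an aromatic carbon. Among the measured compounds shown here, no measured pair isolates this change. Compound 1 has a different core and also an aromatic ring at this place, and its 32800 nM gives no sign of a large shift. The expected size of a 1.5-fold lower number from compound 2 to compound 3 (0.17 log units; within the scatter) in this assay is small, within the scatter and slightly toward stronger inhibition. The estimated value for compound 3 is 40000 nM (expected range 17000 nM to 90000 nM).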

Compound 3, half-maximal inhibitory concentration: 11400 nM
For compound 3 the middle estimate is 3.5-fold (0.55 log units) above the measured one; the whole stated range lies above it.
By their numbers in this assay, from the lowest: compound 3; then compounds 1 and 2 (each within the scatter of the next).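

In this assay the aromatic carbon two atoms from the ring nitrogen, para to a chloro group, responds to its substituent: with the core held fixed, phenyl in place of methyl gives a 5.2-fold lower number from compound 2 to compound 3 (0.71 log units; beyond the scatter) as a modest step. Among these compounds, the earlier compounds offered no pair that differed in one place, so this is the first direct reading of the position. Nothing measured here bears on the reason for the step.

Whether the step needs an aromatic ring at this place stays open, as neither a cyclohexyl group nor a butyl chain is among the compounds shown. Also open, on these data alone, is how a basic amine or a carboxylic acid on the phenyl ring would read on this core, and whether fluoro on that ring would shift the number here.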